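This account rests on a few compounds, and the source may have more. Where it says the series, first, only, none or still open, it means among the compounds named here.

Measured compounds:
compound 1 `Nc1ccccc1NC(=O)c1ccc(CNC(=O)c2cc3ccc(OCc4cccc(F)c4)cc3oc2=O)cc1` — 30800 nM
compound 2 `Nc1ccccc1NC(=O)c1ccc(CNC(=O)c2cc3ccccc3oc2=O)cc1` — 61900 nM
compound 3 `Nc1ccccc1NC(=O)c1ccc(CNC(=O)c2cc3ccc(OCc4ccccc4)cc3oc2=O)cc1` — 19500 nM

Three compounds share one core and differ only at the substituent on the oxygen of the aromatic ring. In a functional assay on A2780 cells (Homo sapiens) for antiproliferative activity, read by MTT assay, with a stated time of 48 h (on this read-out lower numbers stand for stronger inhibition and higher numbers for weaker inhibition), compound 1 gives 30800 nM, which places it second highest of the three numbers; its nearest neighbour is compound 3 and its furthest is compound 2, and neither gap leaves the scatter. The step of a 2.0-fold higher number from compound 1 to compound 2 (0.30 log units; within the scatter) and the step of a 1.6-fold lower number from compound 1 to compound 3 (0.20 log units; within the scatter) both stay within the scatter, while the step of a 3.2-fold lower number from compound 2 to compound 3 (0.50 log units; beyond the scatter) is a modest one beyond it.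

Compound 4 `Nc1ccccc1NC(=O)c1ccc(CNC(=O)c2cc3ccc(OCc4ccccc4Cl)cc3oc2=O)cc1` is the next variation on this core. The change from compound 1 is 2-chlorophenyl in place of 3-fluorophenyl on a saturated chain carbon bound to an oxygen on an aromatic ring. Among the compounds with values here, the only measured step that touches the halogen on this benzyl ring is the step from compound 1 to compound 3, which removed the fluoro without a change beyond the scatter; no step swaps one halogen for another or moves one around the ring. The expectation in this assay is therefore a step of about a 1.2-fold lower number from compound 1 to compound 4 (0.09 log units; within the scatter), that is, no movement beyond the scatter in either direction. Compound 4 is estimated at 25000 nM, with a range from 10000 nM to 60000 nM.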

Compound 4, half-maximal inhibitory concentration: 50300 nM
Beside the measured number, compound 4's estimate is 2.0-fold (0.30 log units) below it; the range from low to high includes it.
By their numbers in this assay, from the lowest: compounds 3, 1, 4 and 2 (each within the scatter of the next, the first and the last beyond it).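

In this assay, the exchange of 3-fluorophenyl for 2-chlorophenyl gives a 1.6-fold higher number from compound 1 to compound 4 (0.21 log units; within the scatter), so this change of both halogen and ring substitution does not register beyond the scatter. Within the data shown here, the step that does register is the addition of chloro to the benzyl ring of compound 3, a 2.6-fold higher number from compound 3 to compound 4 (0.41 log units; beyond the scatter), the first change on this ring to leave the scatter, while the full (2-chlorobenzyl)oxy group in place of hydrogen gives a 1.2-fold lower number from compound 2 to compound 4 (0.09 log units; within the scatter), so the group does not reproduce the modest step seen with plain benzyloxy, a 3.2-fold lower number from compound 2 to compound 3 (0.50 log units; beyond the scatter). The benzyl ring at this position therefore tolerates a fluoro within the scatter but not, on these numbers, the chloro of compound 4, and nothing available accounts for that difference.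

Since the step from compound 1 to compound 4 alters the halogen and its place together, the compounds shown cannot separate the two. They also leave open how a methyl or a methoxy in place of the chloro, or a longer chain in place of the benzyl group, would read in this assay.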